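Phenyl in Place of Vinyl: Expecting Compound 4

The compounds below may be only part of what the source reports. "The series", "measured", "known", "first", "only" and "open" are said of these compounds alone.

Measured so far in a functional assay on MCF7 cells (Homo sapiens) for cytotoxicity, read by MTT assay, with a stated time of 72 h; on this read-out lower numbers stand for higher toxicity in this test and higher numbers for lower toxicity in this test:
compound 1 `CCCOC(=O)Nc1ccc([Se]C#N)cc1` gives 67500 nM
compound 2 `C=CCOC(=O)Nc1ccc([Se]C#N)cc1` gives 71200 nM
compound 3 `N#C[Se]c1ccc(NC(=O)Oc2ccccc2)cc1` gives 67800 nM

All three share one core and differ only in the group attached through the oxygen next to the carbonyl. Compound 2 carries the nominally top number of the three, yet its steps to both neighbours are within the scatter: a 1.1-fold higher number from compound 1 to compound 2 (0.02 log units; within the scatter) and a 1.1-fold lower number from compound 2 to compound 3 (0.02 log units; within the scatter). The third comparison, a 1.0-fold higher number from compound 1 to compound 3 (0.00 log units; within the scatter), is likewise within the scatter, so the three measured compounds are indistinguishable in this assay.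

Compound 4 `N#C[Se]c1ccc(NC(=O)OCc2ccccc2)cc1` is not yet measured. Relative to compound 2 the change is phenyl in place of vinyl on a saturated chain carbon bound to an oxygen next to a carbonyl group. Among the compounds with values here, the closest precedent is the swap of propyl or allyl for phenyl directly on that oxygen, which moved nothing beyond the scatter, and the small vinyl-for-ethyl exchange on the chain carbon was equally flat. On that basis a step of no size beyond the scatter is expected for compound 4, in this assay; the expected step is a 1.0-fold lower number from compound 2 to compound 4 (0.01 log units; within the scatter). Compound 4 is therefore estimated at 70000 nM, with a range from 35000 nM to 140000 nM.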

Compound 4, concentration lethal to 50% of the cells: 68900 nM
For compound 4 the middle estimate is 1.0-fold (0.01 log units) above the measured one; measured number inside the range.
By their numbers in this assay, from the lowest: compounds 1, 3, 4 and 2 (each within the scatter of the next).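

In this assay, the new comparison is a 1.0-fold lower number from compound 2 to compound 4 (0.01 log units; within the scatter) for a much larger exchange than any earlier one on the saturated chain carbon bound to an oxygen next to a carbonyl group: phenyl, with 6 heavy atoms and one six-membered aromatic ring, replaces vinyl, with 2 heavy atoms and no ring. Within the data shown here, measured against the compound with a fully saturated chain, the result is the same, with a 1.0-fold higher number from compound 1 to compound 4 (0.01 log units; within the scatter) when phenyl takes the place of ethyl at this carbon, so this position has now taken on an aromatic ring without the number leaving the scatter, which the earlier compounds, with phenyl only directly on the oxygen, could not show. Nothing in the data explains why the number stays flat through this change.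

The compounds shown leave open whether a different kind of group at this place, such as an amine or a carboxylic acid, or a longer chain, would shift the number beyond the scatter. They also leave open whether the same flat pattern would appear in any test other than this assay.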